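Trifluoromethyl for Isopropoxy, Repeated on a Second Core

This account rests on a few compounds, and the source may have more. Where it says the series, first, only, none or still open, it means among the compounds named here.

Compound 1 `CC(C)Oc1ccc(NC(=O)C(=O)c2cn(C(C)C)c3ccccc23)cn1` was tested in a functional assay on FaDu cells (Homo sapiens) for cytotoxicity, read by MTT assay, with a stated time of 72 h (a higher number here means that more compound is tolerated, a lower number that less compound is tolerated), where compound 1 gives 408 nM. Compound 2 `CC(C)n1cc(C(=O)C(=O)Nc2ccc(C(F)(F)F)nc2)c2ccccc21` differs from it by trifluoromethyl in place of isopropoxy on an aromatic carbon. In this assay compound 2 reaches only a limit of the assay, > 10000 nM. That swap thus produced an at least 24-fold higher number from compound 1 to compound 2 (1.38 log units; beyond the scatter), a step bounded by the limit of > 10000 nM in this assay, at which 1 of the 3 values shown sits. Compound 3 `COCCn1cc(C(=O)C(=O)Nc2ccc(OC(C)C)nc2)c2ccccc21` carries a different core: it differs from compound 1 by 2-methoxyethyl in place of isopropyl on an aromatic nitrogen. In this assay compound 3 gives 55 nM, which is a 7.4-fold lower number from compound 1 to compound 3 (0.87 log units; beyond the scatter). Compound 4 `COCCn1cc(C(=O)C(=O)Nc2ccc(C(F)(F)F)nc2)c2ccccc21` is not yet measured; it differs from compound 3 by trifluoromethyl in place of isopropoxy on an aromatic carbon, the same change seen from compound 1 to compound 2, at the same place. Whether the second core alters the outcome of this swap cannot be read from the two measured steps. Because the same change gave an at least 24-fold higher number from compound 1 to compound 2 (1.38 log units; beyond the scatter), compound 4 is expected to show a 55-fold higher number from compound 3 to compound 4 (1.74 log units; beyond the scatter) in this assay. The estimate for compound 4 is 3000 nM, with a range from 500 nM to 20000 nM, and a fair chance that only a limit is reported.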

Compound 4, concentration lethal to 50% of the cells: > 10000 nM
Compound 4 gave a limit, no number; the forecaster's own chance of this, stated with the estimate: 50%; middle value at least 3.3-fold (0.52 log units) away from the limit.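

In this assay, trifluoromethyl in place of isopropoxy gives an at least 180-fold higher number from compound 3 to compound 4 (2.25 log units; beyond the scatter), so the change that raised the tolerated concentration on the core of compound 1 does the same on the core of compound 3. Compound 4 reaches only a limit of the assay, > 10000 nM. The direction of the change therefore carries over from one core to the other, but its size cannot be compared, and the step from compound 2 to compound 4 cannot be read either, because both of these compounds sit at a limit: the same change on two cores in this assay, an at least 24-fold higher number (1.38 log units; beyond the scatter) from compound 1 to compound 2 and an at least 180-fold higher number (2.25 log units; beyond the scatter) from compound 3 to compound 4; the limit leaves it open whether they differ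

The compounds shown leave open how much less cytotoxic the two trifluoromethyl compounds really are, and whether 2-methoxyethyl still matters once trifluoromethyl is present. They also leave open whether an amine or a carboxylic acid in place of isopropoxy would keep the cytotoxicity of compound 3, which gives 55 nM.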